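Working notes: side-chain exchange, oral tail flick read-out

This account rests on a few compounds, and the source may have more. Where it says the series, first, only, none or still open, it means among the compounds named here.

Measured so far:
compound 1 `O=C(CN(c1ncnc2c1ncn2C1CCCCO1)C1CC1)N[C@@H](CCC(=O)OCc1ccccc1)C(=O)OCc1ccccc1`: 14.1%
compound 2 `O=C(OCc1ccccc1)[C@@H]1CCCN1C(=O)CN(c1nc(Cl)nc2[nH]cnc12)C1CC1`: 31.1%
compound 3 `CSCC[C@H](NC(=O)CN(c1nc(Cl)nc2[nH]cnc12)C1CC1)C(=O)OCc1ccccc1`: 17.6%

In a functional assay on the whole organism (Tail, strain ICR) with Mus musculus as the target, in the tail flick test, with a stated time of 150 min, at a dose of 25 umol/kg by the oral route (on this read-out lower numbers stand for a weaker effect and higher numbers for a stronger effect at the one dose given), compound 1 gives 14.1%, the lowest of the three numbers. Its nearest neighbour on this read-out is compound 3 with 17.6%, a gap within the usual scatter, so the two cannot be placed in any order. Compound 2 with 31.1% sits furthest off, beyond the scatter. Among the measured compounds shown here, compound 1 and compound 3 share neither the same core nor the same side chain, so their two values show only that a change of both parts together left the read-out much where it was.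

Compound 4 `CSCC[C@H](NC(=O)CN(c1ncnc2c1ncn2C1CCCCO1)C1CC1)C(=O)OCc1ccccc1` is still to be measured in this assay. It keeps the core of compound 1 and differs from it only in the side chain: methylsulfanyl in place of benzyloxycarbonyl on a saturated chain carbon, three bonds along the chain from an amide-type nitrogen and a carbonyl carbon. The same methylsulfanyl chain is carried by compound 3, whose value lies within the scatter of compound 1. For the measured compounds named here, no direct step for this change has been measured on either core. The step of a number 2.9 percentage points higher from compound 1 to compound 4 (within the scatter) is therefore expected to be small, in no clear direction, and not beyond the scatter. For compound 4 a value of about 17% is estimated, in the range 6% to 30%.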

Compound 4, a percentage reported as activity, at one dose (the size of the read-out at that dose, not a potency): 17.5%
Compound 4: middle estimate off by 0.5 percentage points, on the low side; measured number inside the range.
By their numbers in this assay, from the lowest: compounds 1, 4 and 3 (each within the scatter of the next); then compound 2.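

Working notes, continued: in this assay, the exchange of 2-(benzyloxycarbonyl)ethyl for 2-(methylsulfanyl)ethyl on the core of compound 1 gives the first step in this series that can be read at a single position, a number 3.4 percentage points higher from compound 1 to compound 4 (within the scatter). At this position and at the one dose and time tested, the benzyloxycarbonyl group, with 10 heavy atoms and its six-membered aromatic ring, can therefore give way to methylsulfanyl, with 2 heavy atoms and no ring, without a change in the read-out beyond the scatter. No measurement at hand accounts for this result.

The compounds shown leave open whether this step would read the same on the core of compound 3, since no pair on that core differs in this side chain alone. They also leave open what a carboxylic acid, a primary amine or a longer chain on a saturated chain carbon, three bonds along the chain from an amide-type nitrogen and a carbonyl carbon, would do in this assay.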